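The source may report more compounds than this note shows. Statements on the series, on what has been measured and on what is new or still open speak of the compounds shown alone.

In a functional assay on RAW264.7 cells (Mus musculus) for inhibition, read by fluorescence, with stated times of 1 h, 24 h and 30 min (on this read-out higher numbers stand for weaker inhibition and lower numbers for stronger inhibition), compound 3 `O=C(/C=C/c1ccccc1C(F)(F)F)c1ccccc1O` has no single number, its result being "not determined" (no result reported) here. Compound 1 `O=C(/C=C/c1ccccc1F)c1cccc(O)c1` gives > 10000 nM as a limit of the assay. Compound 2 `O=C(/C=C/c1ccccc1C(F)(F)F)c1ccccc1` gives > 10000 nM as a limit of the assay too. Compound 4 `O=C(/C=C/c1ccccc1C(F)(F)F)c1cccc(O)c1` has 3-hydroxyphenyl in place of 2-hydroxyphenyl on a carbonyl carbon, a change counted as 3-hydroxyphenyl in place of 2-hydroxyphenyl on a carbonyl carbon with the same atoms joined differently. Among the compounds with values here, no measured step gives a size for this change, so no shift beyond the usual scatter is expected in this assay and weak inhibition is the expectation. That expectation rests on compound 1, which also carries 3-hydroxyphenyl and reads > 10000 nM as a limit. The estimated value for compound 4 is 8000 nM with an expected range from 2000 nM to 25000 nM in this read-out.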

Compound 4, half-maximal inhibitory concentration: > 10000 nM
Compound 4: a limit, no number; the forecaster's own chance of this, stated with the estimate: 55%; at least 1.2-fold (0.09 log units) between middle value and limit.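

The steps from compound 1 and from compound 2 to compound 4 cannot be read in this assay, as all three values are limits: the limit of > 10000 nM in this assay, at which 3 of the 4 values shown sit. The compounds shown leave open how strongly any of them inhibits, and whether 3-hydroxyphenyl and 2-hydroxyphenyl differ here.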